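Three Limits and a Second Methoxy Group

The source may hold more compounds than are shown below. What is called first, only, known or untested is meant among the compounds shown, and "the series" means these compounds.

Three measured compounds share one core. Compound 1, `COc1ccc(/C(Cl)=C/C=C(\C#N)C(=O)c2c[nH]c3ccc(Br)cc23)cc1OC`, carries a bromo group. In a functional assay on MCF7 cells (Homo sapiens) for cytotoxicity, read by sulforhodamine B assay, with a stated time of 48 h (a higher number here means that more compound is tolerated, a lower number that less compound is tolerated), compound 1 gives only the limit of the measurement, > 100000 nM. Compound 2, `COc1ccc(/C(Cl)=C/C=C(\C#N)C(=O)c2c[nH]c3ccccc23)cc1OC`, differs by hydrogen in place of bromo on an aromatic carbon. In this assay compound 2 likewise gives only a limit, > 100000 nM. The recorded step, a step that the two limits leave unreadable from compound 1 to compound 2, therefore cannot be sized. Compound 3, `COc1ccc(/C(Cl)=C/C=C(\C#N)C(=O)c2c[nH]c3ccc(OC)cc23)cc1`, carries a methoxy group instead. In this assay compound 3 again gives only a limit, > 100000 nM. Every value shown sits at one point, (the limit of > 100000 nM in this assay, at which 3 of the 3 values shown sit), so compound 3 stands exactly where all its neighbours stand.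

Compound 4, `COc1ccc2[nH]cc(C(=O)/C(C#N)=C/C=C(\Cl)c3ccc(OC)c(OC)c3)c2c1`, differs from compound 3 by methoxy in place of hydrogen on an aromatic carbon. No measured step gives a readable size for a change of this kind in this assay, and nothing in the values suggests a move away from the limit. The expected step, a step that the limit leaves unreadable from compound 3 to compound 4, is estimated to lie within the scatter. Compound 4 is estimated at 150000 nM, with an expected range from 50000 nM to 500000 nM.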

Compound 4, concentration lethal to 50% of the cells: > 100000 nM
Compound 4: a limit, no number; the forecaster's own chance of this, stated with the estimate: 85%; the middle value does not contradict the limit.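

The steps to compound 4 from compound 1, compound 2 and compound 3 cannot be read in this assay, so none of them has a size: the limit of > 100000 nM in this assay, at which 4 of the 4 values shown sit.

The compounds shown leave open how far each of the four lies past that limit, and whether swapping hydrogen, bromo or methoxy on the shared core changes cytotoxicity at all.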